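This account rests on a few compounds, and the source may have more. Where it says the series, first, only, none or still open, it means among the compounds named here.

Three compounds with a shared core and a saturated chain have been measured in a functional assay on HEK293 cells for agonist activity at G-protein coupled receptor 84 (Homo sapiens), read by calcium flux; a higher number here means that more compound is needed for the effect, a lower number that less compound is needed. Compound 1, `CCCCCc1nc(O)cc(O)n1`, gives 3670 nM in this assay. Compound 2, `CCCCCCCc1cc(O)cc(O)n1`, gives 1.26 nM, and compound 3, `CCCCCCCCNc1nc(O)cc(O)n1`, gives 6.14 nM. Compound 1 therefore stands with the highest number of the three; compound 3 is nearest to it, and compound 2 furthest, both well outside the usual scatter.

Compound 4, `N#CCCCCc1nc(O)cc(O)n1`, has not been measured in this assay. Its structure differs from compound 1 in one place: cyano in place of methyl on a saturated chain carbon, four bonds along the chain from an aromatic carbon. Going by the values given here, no measured pair shows exactly this kind of change, so no step for it is known. The two compounds with lower numbers than compound 1 both carry a longer uninterrupted chain, which compound 4 does not.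

An increase in the number is expected for compound 4, by a step estimated as a 2.7-fold higher number from compound 1 to compound 4 (0.44 log units; beyond the scatter), beyond the scatter. Compound 4 is thus expected to give about 10000 nM, within a range from 3000 nM to 40000 nM.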

Compound 4, half-maximal effective concentration: > 100000 nM
Compound 4: a limit, no number (the forecaster's own chance of this, stated with the estimate: 25%); middle value at least 10-fold (1.00 log units) away from the limit.
By their numbers in this assay, from the lowest: compound 2; then compound 3; then compound 1. At a limit, above all of these: compound 4.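

In this assay compound 4 gives > 100000 nM, which is a limit of the assay and not a number: the limit of > 100000 nM in this assay, at which 1 of the 4 values shown sits.

Cyano in place of methyl at this chain end gives an at least 27-fold higher number from compound 1 to compound 4 (1.43 log units; beyond the scatter). This is the only pair shown that differs in one place, so it is the only direct reading of a single change on this chain, and at this position the change leaves more compound needed for the effect.

The compounds shown leave open whether a hydroxyl, an amine or a carboxylic acid at the same place would also raise the number, and whether a cyano group at the end of a longer chain would do so. Compound 2 and compound 3 differ from compound 1 in more than one place, so they cannot settle this.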